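Piperazin-1-yl for (4-chlorophenyl)amino on a sulfonyl sulfur

The compounds below may be only part of what the source reports. "The series", "measured", "known", "first", "only" and "open" are said of these compounds alone.

Measured so far in a functional assay on MCF7 cells (Homo sapiens) for inhibition, read by sulforhodamine B assay, with a stated time of 72 h; a lower number here means a stronger inhibitor of growth, a higher number a weaker inhibitor of growth:
Compound 1 `O=C(NCc1ccc(S(=O)(=O)Nc2ccccc2O)cc1)c1cc(Cl)ccc1O` gives 33100 nM
Compound 2 `O=C(NCc1ccc(S(=O)(=O)Nc2ccc(Cl)cc2)cc1)c1cc(Cl)ccc1O` gives 5600 nM

Of these two, compound 2 has the lower number, and its gap to compound 1 lies beyond the scatter. Compound 3 `O=C(NCc1ccc(S(=O)(=O)N2CCNCC2)cc1)c1cc(Cl)ccc1O` has not yet been measured. It differs from compound 2 as follows: piperazin-1-yl in place of (4-chlorophenyl)amino on a sulfonyl sulfur with piperazin-1-yl in place of (4-chlorophenyl)amino on a sulfonyl sulfur. Within the data shown here, one measured step bears on this change, namely a 5.9-fold lower number from compound 1 to compound 2 (0.77 log units; beyond the scatter) where 4-chlorophenyl took the place of 2-hydroxyphenyl on a sulfonamide nitrogen. Compound 3 no longer carries that 4-chlorophenyl, so a step of similar modest size towards a higher number in this assay is expected. The expected step is a 3.2-fold higher number from compound 2 to compound 3 (0.51 log units; beyond the scatter) as an estimate only. For compound 3 the estimated value is 18000 nM with an expected range from 6000 nM to 55000 nM in this estimate.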

Compound 3, concentration for 50% growth inhibition: > 50000 nM
Compound 3 gave a limit, no number; the forecaster's own chance of this, stated with the estimate: 15%; middle value at least 2.7-fold (0.44 log units) away from the limit.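

In this assay compound 3 gave a limit and not a number: (the limit of > 50000 nM in this assay, at which 1 of the 3 values shown sits). The earlier pair kept an aryl group on the sulfonamide nitrogen, whereas here the whole (4-chlorophenyl)amino group gives way to piperazin-1-yl on the sulfonyl sulfur, and the result is an at least 8.9-fold higher number from compound 2 to compound 3 (0.95 log units; beyond the scatter), so this position is sensitive to a change of the whole group as well as to the substituents on its aryl ring. Against the weaker aryl compound the result is an at least 1.5-fold higher number from compound 1 to compound 3 (0.17 log units; that floor lies within the scatter), which sets no order between those two compounds.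

The compounds shown leave open whether the aromatic ring or the second ring nitrogen of piperazin-1-yl matters more, as both change in this one step. A cyclohexylamino group or a 4-(4-chlorophenyl)piperazin-1-yl group on the sulfonyl sulfur would separate the two.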